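Cyclopropyl to Methoxymethyl on the Amide of Compound 1

The source may hold more compounds than are shown below. What is called first, only, known or untested is meant among the compounds shown, and "the series" means these compounds.

compound 1 `CC(C)CC(=O)N1CCc2cc(CNC(=O)C3CC3)ccc21`: 35%
compound 2 `CC(C)C(=O)N1CCc2cc(CNC(=O)c3ccccc3)ccc21`: 100%
compound 3 `CCC(=O)N1CCc2cc(CNC(=O)c3cccc(Cl)c3)ccc21`: 77%

Of the compounds shown here, three built on a shared core have been measured in an assay on HEK293 cells for inhibition of Indoleamine 2,3-dioxygenase 1 (Homo sapiens), tested at 10 uM; a higher number here means more inhibition at the concentration tested (going by the name of the read-out), a lower number less inhibition. Compound 1 gives 35%, the lowest of the three numbers. The nearest number belongs to compound 3, which gives 77%, a gap beyond the usual scatter. The furthest belongs to compound 2, which gives 100%, also beyond the scatter. Compounds 2 and 3 differ from compound 1 in more than one place, so no single exchange between measured compounds can be read off from these three values.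

The next compound, compound 4 `COCC(=O)NCc1ccc2c(c1)CCN2C(=O)CC(C)C`, differs from compound 1 in one place only: methoxymethyl in place of cyclopropyl on a carbonyl carbon. Within the data shown here, no measured pair shows this exchange, so the size of its effect in this assay is open. Since the replacement keeps the same count of heavy atoms and touches only the group on the carbonyl carbon, the step is expected to be small, most likely none beyond the scatter, if anything slightly downward from compound 1.

Compound 4 is therefore expected to give about 30% in this assay, with a range from 10% to 55%. That estimate means a step of a number 5 percentage points lower from compound 1 to compound 4 (within the scatter), expected to stay within the scatter.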

Compound 4, a percentage reported as inhibition, at one concentration (the size of the read-out at that concentration, not a potency): 20%
The estimate for compound 4 lay 10 percentage points above the measured number, and the stated range covers the measured number.
By their numbers in this assay, from the lowest: compound 4; then compound 1; then compound 3; then compound 2.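

In this assay, the exchange of cyclopropyl for methoxymethyl on a carbonyl carbon whose other neighbour is an amide-type nitrogen gives a modest step, a number 15 percentage points lower from compound 1 to compound 4 (beyond the scatter), so the number responds to this change even though the count of heavy atoms stays the same. This is the first single exchange that can be read directly from the compounds shown, and it shows that replacing the three-membered ring with an open group carrying a hydrogen-bond acceptor does not raise the number at this position. Nothing available bears on what lies behind the step.

The compounds shown do not separate the loss of the ring from the entry of the oxygen, a question that a propyl group on the same carbonyl carbon, with an open chain and no oxygen, could help to settle. As far as these compounds go, it also remains open how a dimethylaminomethyl group or a carboxylic acid would read at this place, and whether the methoxymethyl exchange would give a similar step on the other compounds.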